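Working notes: from compound 2 to compound 4

The compounds below may be only part of what the source reports. "The series", "measured", "known", "first", "only" and "open" are said of these compounds alone.

- compound 1 `O=C(CCCCCNC(=S)NN=C(c1ccccn1)c1ccccn1)NO` gives 2870 nM
- compound 2 `O=C(CCCCCNC(=S)N/N=C(\c1ccccc1)c1ccccn1)NO` gives 2140 nM
- compound 3 `C/C(=N\NC(=S)NCCCCCC(=O)NO)c1cccc(C(F)(F)F)c1` gives 1400 nM

In a functional assay on K562 cells (Homo sapiens) for antiproliferative activity, read by MTT assay (on this read-out lower numbers stand for stronger inhibition and higher numbers for weaker inhibition), compound 2 stands at 2140 nM, within the scatter of both compound 1 and compound 3. The next analogue, compound 4 `O=C(CCCCCNC(=S)N/N=C(\c1ccccc1)c1ccc([N+](=O)[O-])cc1)NO`, carries 4-nitrophenyl in place of pyridin-2-yl on a carbon with a double bond to nitrogen. Among the compounds with values here, no measured pair isolates this change, so its size is not known from the data. With nothing to suggest a larger shift, no step beyond the scatter is expected in this assay. The step of a 1.1-fold lower number from compound 2 to compound 4 (0.05 log units; within the scatter) is an expected one and remains small. The estimate for compound 4 is 1900 nM, with an expected range of 750 nM to 4800 nM.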

Compound 4, half-maximal inhibitory concentration: 2890 nM
The estimate for compound 4 lay 1.5-fold (0.18 log units) below the measured number, within the range that was stated.
By their numbers in this assay, from the lowest: compounds 3, 2, 1 and 4 (each within the scatter of the next, the first and the last beyond it).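

In this assay the only single-place change shown gives a 1.4-fold higher number from compound 2 to compound 4 (0.13 log units; within the scatter) when 4-nitrophenyl replaces pyridin-2-yl on a carbon with a double bond to nitrogen. At this place, then, a ring of carbon only bearing a nitro group and a ring with one hetero atom cannot be told apart in this read-out. Nothing available explains the result.

As far as these compounds go, whether an amine or a carboxylic acid in place of the nitro group would give a step beyond the scatter remains open. From the compounds shown here alone, the effect of a longer chain on the shared core also remains open.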